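Methyl for Methoxy on a Fused Ring, Second Occurrence

The source may report more compounds than this note shows. Statements on the series, on what has been measured and on what is new or still open speak of the compounds shown alone.

Of the compounds shown here, three sharing one amide-linked scaffold have been measured in a functional assay on PC-3 cells (Homo sapiens) for cytotoxicity, read by MTT assay, with a stated time of 72 h; on this read-out higher numbers stand for weaker inhibition and lower numbers for stronger inhibition. Compound 1 `COc1ccc2nc(NC(=O)c3cn(-c4ccccc4)nc3-c3ccccc3)sc2c1` gives 17500 nM in this assay. Compound 2 `Cc1ccc2nc(NC(=O)c3cn(-c4ccccc4)nc3-c3ccccc3)sc2c1` gives 15700 nM in this assay. Compound 3 `COc1ccc(-c2nn(-c3ccccc3)cc2C(=O)Nc2nc3ccc(OC)cc3s2)cc1` gives 13500 nM in this assay. All three numbers lie within the scatter of one another, so no order among them can be claimed.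

The change from compound 1 to compound 2 is methyl in place of methoxy on an aromatic carbon and it produced a 1.1-fold lower number from compound 1 to compound 2 (0.05 log units; within the scatter). Compound 3 differs from compound 1 in a different part of the molecule, namely (methoxy in place of hydrogen on an aromatic carbon), which gave a 1.3-fold lower number from compound 1 to compound 3 (0.11 log units; within the scatter).

Compound 4 `COc1ccc(-c2nn(-c3ccccc3)cc2C(=O)Nc2nc3ccc(C)cc3s2)cc1` has not yet been measured. It stands to compound 3 as compound 2 stands to compound 1: the difference is methyl in place of methoxy on an aromatic carbon, made on the core of compound 3 rather than the core of compound 1. The place of the change is the same in both pairs, so this is the same change carried onto a core that already carries the methoxy described above.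

In this assay the step from compound 3 to compound 4 is expected to be about a 1.1-fold lower number from compound 3 to compound 4 (0.03 log units; within the scatter), resting on the earlier pair, where compound 1 to compound 2 gave a 1.1-fold lower number from compound 1 to compound 2 (0.05 log units; within the scatter), a step within the scatter. Compound 4 is therefore estimated at 12500 nM in this assay, with a likely range from 6000 nM to 26000 nM.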

Compound 4, half-maximal inhibitory concentration: 15900 nM
Compound 4: middle estimate off by 1.3-fold (0.10 log units), on the low side; low and high end bracket the measured number.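

In this assay, going from 6-methoxy-1,3-benzothiazol-2-yl to 6-methyl-1,3-benzothiazol-2-yl on the core of compound 3 gave a 1.2-fold higher number from compound 3 to compound 4 (0.07 log units; within the scatter), and methoxy in place of hydrogen on an aromatic carbon, read on the core of compound 2, gave a 1.0-fold higher number from compound 2 to compound 4 (0.01 log units; within the scatter). The methyl-for-methoxy change reads alike on both cores, with no difference between them that can be claimed: the same change on two cores in this assay, a 1.1-fold lower number (0.05 log units; within the scatter) from compound 1 to compound 2 and a 1.2-fold higher number (0.07 log units; within the scatter) from compound 3 to compound 4, 1.3-fold (0.12 log units) apart, within the scatter of two such steps. Among these compounds, the methoxy-for-hydrogen change reads the same way, but no step here stands clear of the scatter on either core, so the four compounds show no effect that carries from one core to another, and they equally do not show that a larger effect would fail to carry over: the same change on two cores in this assay, a 1.3-fold lower number (0.11 log units; within the scatter) from compound 1 to compound 3 and a 1.0-fold higher number (0.01 log units; within the scatter) from compound 2 to compound 4, 1.3-fold (0.12 log units) apart, within the scatter of two such steps.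

As far as these compounds go, what stays open is whether a different group at the place of the methyl and methoxy, such as an amine, a carboxylic acid or a longer chain, would give a step beyond the scatter on these cores. The same question stands for the place where compound 3 and compound 4 carry their other methoxy, where a fluorine or a hydroxyl could be set beside it.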